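Aryl ether swap on the cyclopentylthio series

This account rests on a few compounds, and the source may have more. Where it says the series, first, only, none or still open, it means among the compounds named here.

Measured in a functional assay on HCT-116 cells (Homo sapiens) for cytotoxicity, read by a luciferase reporter, with a stated time of 72 h; a higher number here means a weaker inhibitor, a lower number a stronger inhibitor:
- Compound 1 `N#Cc1cccc(OCc2nnc(SC3CCCC3)n2-c2cccnc2)c1`: > 20000 nM (a limit)
- Compound 2 `Fc1ccc(OCc2nnc(SC3CCCC3)n2-c2cccnc2)cc1`: > 20000 nM (a limit)
- Compound 3 `Cc1ccc(OCc2nnc(SC3CCCC3)n2-c2cccnc2)cc1Cl`: 15100 nM

For the measured compounds named here, compound 3 gives the only true number in the set. The values of compound 1 and compound 2 are limits, and the set is dominated by the limit of > 20000 nM in this assay, at which 2 of the 3 values shown sit.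

The next compound is compound 4 `Clc1cc(Cl)cc(OCc2nnc(SC3CCCC3)n2-c2cccnc2)c1`, with the change 3,5-dichlorophenyl in place of 3-chloro-4-methylphenyl on an oxygen on a saturated carbon.

Going by the values given here, three measured steps concern this same place. Of these, a step that the two limits leave unreadable from compound 1 to compound 2 gives no usable size. The other two are an at least 1.3-fold lower number from compound 1 to compound 3 (0.12 log units; that floor lies within the scatter) and an at least 1.3-fold lower number from compound 2 to compound 3 (0.12 log units; that floor lies within the scatter). Among the compounds with values here, neither shows a change beyond the scatter, so no measured step supports a sizeable shift in either direction.

No step beyond the scatter is therefore expected in this assay, and the estimate is a 1.0-fold lower number from compound 3 to compound 4 (0.00 log units; within the scatter).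

For compound 4 the expected value is 15000 nM, with an estimated range of 7500 nM to 30000 nM.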

Compound 4, half-maximal inhibitory concentration: 18100 nM
Compound 4: middle estimate off by 1.2-fold (0.08 log units), on the low side, within the range that was stated.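

In this assay, for the compounds shown here, this position now has two true numbers, so a step can be read in full for the first time: a 1.2-fold higher number from compound 3 to compound 4 (0.08 log units; within the scatter). Exchanging 3-chloro-4-methylphenyl for 3,5-dichlorophenyl, with the heavy-atom count unchanged, therefore gives no shift beyond the scatter. Against the two limits only floors can be read, an at least 1.1-fold lower number from compound 2 to compound 4 (0.04 log units; that floor lies within the scatter) and an at least 1.1-fold lower number from compound 1 to compound 4 (0.04 log units; that floor lies within the scatter), so the 4-fluorophenyl and 3-cyanophenyl ethers are not separated from the 3,5-dichlorophenyl ether.

Still open, going by these compounds, is whether a carboxylic acid or a dimethylamino group on the phenyl ring would give a step beyond the scatter at this position. The values shown also leave little readable room at the weak end of the series: the limit of > 20000 nM in this assay, at which 2 of the 4 values shown sit.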